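Adding a Second Methoxy Group to Compound 3

This account rests on a few compounds, and the source may have more. Where it says the series, first, only, none or still open, it means among the compounds named here.

Three compounds have been measured in a functional assay on MCF7 cells (Homo sapiens) for cytotoxicity, read by MTT assay, with a stated time of 48 h; a higher number here means a weaker inhibitor, a lower number a stronger inhibitor:

compound 1, `COc1ccc(-c2cc(C(=O)Nc3nc4ccc(OC)cc4s3)nc3cc(-c4ccccc4)nn23)cc1`, gives 19100 nM
compound 2, `COc1ccc(-c2cc(C(=O)Nc3nc4ccccc4s3)nc3cc(-c4ccccc4)nn23)cc1`, gives 2230 nM
compound 3, `COc1ccc(-c2cc(C(=O)Nc3nc4cc(C)c(C)cc4s3)nc3cc(-c4ccccc4)nn23)cc1`, gives 19700 nM

Compound 3 differs from compound 2 by 5,6-dimethyl-1,3-benzothiazol-2-yl in place of 1,3-benzothiazol-2-yl on an amide-type nitrogen, and that change produced an 8.8-fold higher number from compound 2 to compound 3 (0.95 log units; beyond the scatter). Compound 1 and compound 3 show a 1.0-fold higher number from compound 1 to compound 3 (0.01 log units; within the scatter).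

The change from compound 2 to compound 1 is methoxy in place of hydrogen on an aromatic carbon, and it gave an 8.6-fold higher number from compound 2 to compound 1 (0.93 log units; beyond the scatter). Compound 4, `COc1ccc(-c2cc(C(=O)Nc3nc4cc(C)c(C)cc4s3)nc3cc(-c4ccccc4)nn23)cc1OC`, is obtained from compound 3 by methoxy in place of hydrogen on an aromatic carbon. This is the same kind of change, not the same one: in compound 1 the methoxy enters on a ring that is part of a fused or bridged system of two rings, meta to a fused ring and para to a fused ring, whereas in compound 4 it enters ortho to a methoxy group and meta to a large group.

Since the earlier step weakened the compound, and compound 3 already gives 19700 nM, compound 4 is expected to give a similar or higher number, with the estimated step of a 1.4-fold higher number from compound 3 to compound 4 (0.15 log units; within the scatter). Compound 4 is estimated at 28000 nM, between 9000 nM and 90000 nM.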

Compound 4, half-maximal inhibitory concentration: 2510 nM
Estimate against measurement, compound 4: 11-fold (1.05 log units) above, outside the stated range (below it).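

In this assay, methoxy in place of hydrogen on the 4-methoxyphenyl group, which turns it into 3,4-dimethoxyphenyl, gave a 7.8-fold lower number from compound 3 to compound 4 (0.89 log units; beyond the scatter). Set beside the earlier methoxy step, the change did not carry over from one core to the other, and the two steps run in opposite directions: the same change on two cores in this assay, an 8.6-fold higher number (0.93 log units; beyond the scatter) from compound 2 to compound 1 and a 7.8-fold lower number (0.89 log units; beyond the scatter) from compound 3 to compound 4, 67-fold (1.83 log units) apart, beyond the scatter of two such steps This shows that the name of the change alone does not predict its outcome in this series, but it does not show what sets the outcome, since the two steps differ both in the ring that takes the methoxy, a 1,3-benzothiazol-2-yl ring in one and a phenyl ring in the other, and in the rest of the molecule.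

From the compounds shown here alone, it remains open how the 3,4-dimethoxyphenyl group behaves with the unsubstituted 1,3-benzothiazol-2-yl amide of compound 2, which would test whether the step depends on the 5,6-dimethyl groups. Also open, going by these compounds, is whether an ethoxy or a hydroxyl group in place of the new methoxy would give a similar number.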